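One Methoxy Fewer: Expecting the Effect on Cell Growth

The source may hold more compounds than are shown below. What is called first, only, known or untested is meant among the compounds shown, and "the series" means these compounds.

Of the compounds shown here, three built on one shared core have been tested in a functional assay on A498 cells (Homo sapiens) for cytotoxicity, read by sulforhodamine B assay, with a stated time of 48 h, tested at 10 uM; a lower number here means a stronger effect, a higher number a weaker effect of the compound at the concentration tested. Compound 1 `COc1cc(-c2cc(/C=C/C(=O)c3ccc(N)cc3)[nH]n2)cc(OC)c1OC` gives -43%. Compound 2 `COc1ccc(-c2cc(/C=C/C(=O)c3ccc(OC)c(OC)c3)[nH]n2)cc1` gives -57% in this assay, and compound 3 `COc1cc(-c2cc(/C=C/C(=O)c3ccc(Cl)c(Cl)c3)[nH]n2)cc(OC)c1OC` gives 43%. Among these three numbers compound 1 stands second highest: compound 2 lies lower and compound 3 lies far higher, both beyond the scatter. Within the data shown here, the only single change measured so far is a number 86 percentage points higher from compound 1 to compound 3 (beyond the scatter), a swap of the group on the carbonyl carbon.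

Compound 4 `COc1ccc(-c2cc(/C=C/C(=O)c3ccc(N)cc3)[nH]n2)cc1OC` is not yet measured. It differs from compound 1 in another part of the molecule: hydrogen in place of methoxy on an aromatic carbon. Among the measured compounds shown here, no measured pair isolates this change. The step from compound 1 to compound 3 concerns the carbonyl side and so does not bear on it directly; it shows only that this assay can move strongly with structure. Compound 2 also lacks two of the methoxy groups of compound 1, yet it differs in a second place too, so its value near that of compound 1 is only a weak hint that fewer methoxy groups need not weaken the effect. The expectation is therefore a step of no size beyond the scatter, a number 8 percentage points higher from compound 1 to compound 4 (within the scatter), held with wide uncertainty. Compound 4 is estimated at -35%, within the range -70% to 10%.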

Compound 4, a percentage reported as activity, at one concentration (the size of the read-out at that concentration, not a potency): -16%
For compound 4 the middle estimate is 19 percentage points below the measured one; the range from low to high includes it.
By their numbers in this assay, from the lowest: compound 2; then compound 1; then compound 4; then compound 3.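

The methoxy group at this position counts for something: with hydrogen in its place, ortho to a methoxy group and meta to a large group, this assay gives a number 27 percentage points higher from compound 1 to compound 4 (beyond the scatter), which is a weaker effect at the concentration tested. Among these compounds, this is the first single change read on this side of the molecule, and it is a modest step, set against a number 86 percentage points higher from compound 1 to compound 3 (beyond the scatter) for the swap on the carbonyl side, so the result depends on both ends of the shared core, while compound 4, at -16%, keeps the negative sign of compound 1. Nothing in hand explains why losing this methoxy group weakens the effect.

The compounds shown leave open whether a hydroxyl group, an ethoxy group or a fluorine atom at this position would hold the effect of compound 1 or lose it as hydrogen does. They also leave open what each of the two remaining methoxy groups contributes, and whether the same swap would give a step of similar size with the 3,4-dichlorophenyl group of compound 3 on the carbonyl carbon.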